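A few compounds are considered here, and "the series" means these few. Any claim that something is new, unique, unknown or untested is made for them only; others in the source may bear on it.

Measured so far:
compound 1 `C[C@H](Nc1ncnc2[nH]cnc12)c1nn(-c2ccncc2)c2cc(F)ccc12`: 16%
compound 2 `Cc1ccc2c(c1)c([C@H](C)Nc1ncnc3[nH]cnc13)nn2-c1cccnc1`: -10%

In a functional assay on Bel-7402 cells (Homo sapiens) for inhibition, read by sulforhodamine B assay, with a stated time of 72 h, tested at 10 uM (a higher number here means more inhibition at the concentration tested (going by the name of the read-out), a lower number less inhibition), compound 2 gives -10%, the lowest of the two numbers; its nearest neighbour, compound 1, gives 16%, a gap beyond the scatter. Compound 3 `C[C@H](Nc1ncnc2[nH]cnc12)c1nn(-c2cccnc2)c2ccc(F)cc12` is the compound to be measured next. The change from compound 2 to compound 3 is fluoro in place of methyl on an aromatic carbon. Among the compounds with values here, there is no measured pair in this set that differs in exactly this way, so the size of the step cannot be read from any earlier step. Given that compound 2 sits at the bottom of the range with -10%, the exchange of one small group for another is expected to move the number little, and the step of a number 10 percentage points higher from compound 2 to compound 3 (within the scatter) is estimated to stay within the usual scatter. Compound 3 is therefore expected to give 0% in this assay, with a range from -15% to 20%.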

Compound 3, a percentage reported as inhibition, at one concentration (the size of the read-out at that concentration, not a potency): -22%
Compound 3: the middle estimate sits 22 percentage points above what was measured; the measured number lies below the stated range.
By their numbers in this assay, from the lowest: compound 3; then compound 2; then compound 1.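

In this assay the exchange of methyl for fluoro on this aromatic carbon gives a number 12 percentage points lower from compound 2 to compound 3 (beyond the scatter) and so shows that the number responds to a swap of one heavy atom at this position, though the step is modest. Both members of the pair read below zero, compound 2 at -10% and compound 3 at -22% in this assay, so the change separates two compounds that show no inhibition at the concentration tested and does not reveal a group that confers it. No measurement at hand explains the step.

The compounds shown leave open whether chloro, methoxy or an amine on the same carbon would lift the number above zero. They also leave open whether the same exchange would give a step of similar size in a compound that shows real inhibition.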